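The source may report more compounds than this note shows. Statements on the series, on what has been measured and on what is new or still open speak of the compounds shown alone.

Measured compounds:
- compound 1, `Cn1c(-c2ccccc2C(F)(F)F)nnc1C12CCC(CNS(C)(=O)=O)(CC1)CC2`; in an assay on CHO-K1 cells for inhibition of 11-beta-hydroxysteroid dehydrogenase type 2 (Homo sapiens), read by scintillation proximity assay (on this read-out higher numbers stand for weaker inhibition and lower numbers for stronger inhibition), compound 1 gives > 4000 nM, which is a limit of the assay and not a number.
- compound 2, `CC(C)S(=O)(=O)CCC12CCC(c3nnc(-c4ccccc4C(F)(F)F)n3C)(CC1)CC2`; in this assay compound 2 gives > 4000 nM, again a limit and not a number.

Compound 2 therefore stands at the limit, as does compound 1: both values sit at the limit of > 4000 nM in this assay, at which 2 of the 2 values shown sit. Going by the values given here, the one recorded step, a step that the two limits leave unreadable from compound 1 to compound 2, cannot be read as a size.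

The next compound, compound 3, `CCOCC12CCC(c3nnc(-c4ccccc4C(F)(F)F)n3C)(CC1)CC2`, differs from compound 2 by ethoxy in place of (isopropylsulfonyl)methyl on a saturated chain carbon bound to a saturated ring carbon. Only the unreadable step from compound 1 to compound 2 bears on this change, so no size or direction for this assay can be drawn from the measured pairs; the shared core has so far given only limits.

Compound 3 is accordingly expected to remain weak, with the step that the limit leaves unreadable from compound 2 to compound 3 estimated as no readable change. The estimate for compound 3 in this assay is 8000 nM, between 2000 nM and 40000 nM, most likely reported again as a limit.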

Compound 3, half-maximal inhibitory concentration: > 4000 nM
Compound 3 ended at the assay's limit; the forecaster's own chance of this, stated with the estimate: 80%; the middle value lies beyond the limit too.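

In this assay, going by these compounds alone, compound 3 gives > 4000 nM, a limit and not a number, so no step among compound 1, compound 2 and compound 3 can be read. The compounds shown leave open whether any group at this place on the shared core gives a readable inhibition value.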